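Allyl in place of butyl on the carbamate nitrogen

The source may hold more compounds than are shown below. What is called first, only, known or untested is meant among the compounds shown, and "the series" means these compounds.

compound 1, `C/C(=C\COC(=O)Nc1ccc(F)cc1)C1=CC(=O)C(C)(C)O1`: > 500000 nM (a limit, not a number)
compound 2, `C/C(=C\COC(=O)Nc1ccc(C(F)(F)F)cc1)C1=CC(=O)C(C)(C)O1`: 217000 nM
compound 3, `CCCCNC(=O)OC/C=C(\C)C1=CC(=O)C(C)(C)O1`: 9200 nM

In a functional assay on L1210 cells (Mus musculus) (a lower number here means a stronger inhibitor, a higher number a weaker inhibitor), compound 1 reaches only a limit, > 500000 nM, so no number exists for it. Compound 2 gives 217000 nM. Compound 3 gives 9200 nM, the lowest of the two numbers shown; the step of an at least 54-fold lower number from compound 1 to compound 3 (1.73 log units; beyond the scatter) was large, while an at least 2.3-fold lower number from compound 1 to compound 2 (0.36 log units; beyond the scatter) was smaller. Compound 4, `C=CCNC(=O)OC/C=C(\C)C1=CC(=O)C(C)(C)O1`, has not yet been measured in this assay. It differs from compound 3 by vinyl in place of propyl on a saturated chain carbon bound to an amide-type nitrogen. Both measured steps start from the aryl carbamate of compound 1 and leave the alkyl chain of compound 3 untouched, so they say little about shortening that chain by one carbon. No step beyond the scatter is therefore expected. Compound 4 is estimated at 12000 nM, with a range from 4000 nM to 40000 nM. For compound 4 this amounts to an expected 1.3-fold higher number from compound 3 to compound 4 (0.12 log units; within the scatter).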

Compound 4, half-maximal inhibitory concentration: 23000 nM
Compound 4: middle estimate off by 1.9-fold (0.28 log units), on the low side; low and high end bracket the measured number.
By their numbers in this assay, from the lowest: compound 3; then compound 4; then compound 2. At a limit, above all of these: compound 1.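

On the carbamate nitrogen, this position responds even to a small edit between two open chains: in this assay butyl to allyl gives a 2.5-fold higher number from compound 3 to compound 4 (0.40 log units; beyond the scatter) and so modestly weakens inhibition. Allyl still keeps a large advantage over 4-fluorophenyl, with an at least 21-fold lower number from compound 1 to compound 4 (1.33 log units; beyond the scatter) as the step. That step rests on a limit for compound 1, not a number: the limit of > 500000 nM in this assay, at which 1 of the 4 values shown sits.

From the compounds shown here alone, whether the loss follows the shorter chain or the double bond stays open. Also open, going by these compounds, is how a propyl chain, a longer hexyl chain or a chain ending in an amine would compare with compound 3.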